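The source may report more compounds than this note shows. Statements on the series, on what has been measured and on what is new or still open speak of the compounds shown alone.

Compound 1 `COc1ccc(-c2oc3c(CC=C(C)C)c(OCC(=O)O)cc(O)c3c(=O)c2OCC(=O)O)cc1`: > 100000 nM
Compound 2 `COc1ccc(-c2oc3c(CC=C(C)C)c(OC(C(=O)O)C(=O)O)cc(O)c3c(=O)c2OC(C(=O)O)C(=O)O)cc1`: > 100000 nM
Compound 3 `CCOC(=O)COc1cc(O)c2c(=O)c(O)c(-c3ccc(OC)cc3)oc2c1CC=C(C)C`: 27900 nM

Within the data shown here, in a functional assay on MCF7 cells (Homo sapiens) for cytotoxicity, read by MTT assay (a higher number here means a weaker inhibitor, a lower number a stronger inhibitor), compound 3 gives 27900 nM, the only finished number among the three. For compound 1 the result is a limit, > 100000 nM. For compound 2 the result is likewise a limit, > 100000 nM. Compound 4 `COc1ccc(-c2oc3c(CC=C(C)C)c(OC/C=C/C(=O)O)cc(O)c3c(=O)c2O)cc1` has not yet been tested. It differs from compound 3 in one place: 2-carboxyethenyl in place of ethoxycarbonyl on a saturated chain carbon bound to an oxygen on an aromatic ring. Among the measured compounds shown here, with no measured pair to compare, the size of this step can only be guessed. Because the limit of > 100000 nM in this assay, at which 2 of the 3 values shown sit, a loss of potency, rising toward that limit, seems more likely than a gain. Compound 4 is therefore estimated at 80000 nM, with a range from 25000 nM to 300000 nM, a step of a 2.9-fold higher number from compound 3 to compound 4 (0.46 log units; beyond the scatter) expected.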

Compound 4, half-maximal inhibitory concentration: > 100000 nM
Compound 4 gave a limit, no number; the forecaster's own chance of this, stated with the estimate: 50%; middle value at least 1.2-fold (0.09 log units) away from the limit.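

In this assay, putting 2-carboxyethenyl in place of ethoxycarbonyl on this saturated chain carbon gives an at least 3.5-fold higher number from compound 3 to compound 4 (0.55 log units; beyond the scatter), and the result for compound 4 is a limit, not a number. Compound 4 differs from compound 3 in this one place only, so this single change is enough to lose the finished number. Compound 3 is now the only compound that escapes the limit: the limit of > 100000 nM in this assay, at which 3 of the 4 values shown sit.

Still open, going by these compounds, is how far the number rises with this change. Also open, on these data alone, is whether an amide or an amine in this place would keep a finished number.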